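Swapping the Anilide Group on the Imidazole Analogue

The source may report more compounds than this note shows. Statements on the series, on what has been measured and on what is new or still open speak of the compounds shown alone.

Measured so far:
compound 1 `O=C(Nc1ccc(Oc2ccc(-c3nccs3)cc2)cc1)Nc1ccc(Cl)c([N+](=O)[O-])c1` with 77.1%
compound 2 `O=C(Nc1ccc(Oc2ccc(-c3nccs3)cc2)cc1)Nc1cccc(C(F)(F)F)c1` with 71.5%
compound 3 `O=C(Nc1ccc(Oc2ccc(-c3ncc[nH]3)cc2)cc1)Nc1ccc(Cl)c([N+](=O)[O-])c1` with 12.4%

All three were tested in a functional assay on A549 cells (Homo sapiens) for inhibition, read by MTT assay and WST assay, with a stated time of 72 h, tested at 10 uM; a lower number here means less inhibition of growth, a higher number more inhibition of growth at the concentration tested. Going by the values given here, compound 3 stands lowest of the three: compound 2 is the nearest, and the step from compound 3 to compound 2 lies beyond the scatter, as does the one from compound 3 to compound 1. The large drop came with the ring change, a number 64.7 percentage points lower from compound 1 to compound 3 (beyond the scatter), whereas exchanging the group on the amide-type nitrogen changed little, a number 5.6 percentage points lower from compound 1 to compound 2 (within the scatter).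

Compound 4 `O=C(Nc1ccc(Oc2ccc(-c3ncc[nH]3)cc2)cc1)Nc1ccc(F)c(Cl)c1` is not yet measured. It differs from compound 3 only in that place: 3-chloro-4-fluorophenyl in place of 4-chloro-3-nitrophenyl on an amide-type nitrogen. Among the compounds with values here, the only measured step bearing on this, from compound 1 to compound 2, was within the scatter, so no step beyond the scatter is expected in this assay, in either direction. Compound 4 is therefore estimated to give 12%, between 0% and 32%, a step of a number 0.4 percentage points lower from compound 3 to compound 4 (within the scatter) from compound 3.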

Compound 4, percent growth inhibition at one concentration: 14.6%
Compound 4: the middle estimate sits 2.6 percentage points below what was measured; low and high end bracket the measured number.
By their numbers in this assay, from the lowest: compounds 3 and 4 (each within the scatter of the next); then compounds 2 and 1 (each within the scatter of the next).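

In this assay, exchanging 4-chloro-3-nitrophenyl for 3-chloro-4-fluorophenyl on the amide-type nitrogen gives a number 2.2 percentage points higher from compound 3 to compound 4 (within the scatter), so a group without the nitro and with fewer heavy atoms leaves the number where it stood. The earlier step at this place, a number 5.6 percentage points lower from compound 1 to compound 2 (within the scatter), came from compounds carrying 1,3-thiazol-2-yl, and this pair now shows an equally small step with 1H-imidazol-2-yl, though only two exchanges at this place are shown. No measurement available here explains why the number holds through this change.

Still open, from the compounds shown here alone, is whether a carboxylic acid or an amine on this phenyl ring, or a longer chain in its place, would move the number with 1H-imidazol-2-yl present. Going by these compounds, the effect of 3-chloro-4-fluorophenyl with 1,3-thiazol-2-yl also remains open.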